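A few compounds are considered here, and "the series" means these few. Any claim that something is new, unique, unknown or untested is made for them only; others in the source may bear on it.

Compound 1 `CC1=NC(C)=C(C(=O)OCCCN2C(=O)c3ccccc3S2(=O)=O)C(c2ccccc2[N+](=O)[O-])/C1=C(\O)OC(C)C`: in a functional assay (aorta) with Oryctolagus cuniculus as the target (a higher number here means a weaker inhibitor, a lower number a stronger inhibitor), compound 1 gives 1.2 nM.
Compound 2 `CC1=NC(C)=C(C(=O)OCCCN2C(=O)c3ccccc3S2(=O)=O)C(c2ccccc2[N+](=O)[O-])/C1=C(\O)OCC1CCCO1`: in this assay compound 2 gives 6.8 nM.

Among the measured compounds shown here, of these two numbers, compound 2 holds the higher one, and the single measured step, a 5.7-fold higher number from compound 1 to compound 2 (0.75 log units; beyond the scatter), lies beyond the scatter. Compound 3 `CC1=NC(C)=C(C(=O)OCCCN2C(=O)c3ccccc3S2(=O)=O)C(c2ccccc2[N+](=O)[O-])/C1=C(\O)OCC1CCCCO1` differs from compound 2 by oxan-2-yl in place of oxolan-2-yl on a saturated chain carbon bound to an oxygen on an unsaturated carbon. For the measured compounds named here, no measured step enlarges a ring in this way; the step of a 5.7-fold higher number from compound 1 to compound 2 (0.75 log units; beyond the scatter) altered the same ester group but swapped a chain for a ring, so it guides only loosely. Compound 3 is therefore expected to shift little, with a step of a 1.2-fold higher number from compound 2 to compound 3 (0.07 log units; within the scatter), likely within the scatter. For compound 3 the expected value in this assay is 8 nM, ranging from 3 nM to 25 nM.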

Compound 3, half-maximal inhibitory concentration: 11.5 nM
Estimate against measurement, compound 3: 1.4-fold (0.16 log units) below; measured number inside the range.
By their numbers in this assay, from the lowest: compound 1; then compounds 2 and 3 (each within the scatter of the next).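

Swapping oxolan-2-yl for oxan-2-yl gives a 1.7-fold higher number from compound 2 to compound 3 (0.23 log units; within the scatter) in this assay, so at this position these two ring sizes cannot be told apart. Set against isopropyl, the (oxan-2-yl)methyl group gives a 9.6-fold higher number from compound 1 to compound 3 (0.98 log units; beyond the scatter), which shows that both ring-bearing groups shown here stand apart from isopropyl, by steps beyond the scatter. Nothing shown gives a reason for these numbers.

Still open, on these data alone, is how an open chain such as 2-methoxyethyl would compare with isopropyl. The same holds for a ring carrying an amine, such as (piperidin-2-yl)methyl.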